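Compound 3 gains a fluoro: an expected step

The compounds below may be only part of what the source reports. "The series", "measured", "known", "first", "only" and "open" are said of these compounds alone.

Among the compounds with values here, in a functional assay on MCF7 cells (Homo sapiens) for cytotoxicity, read by MTT assay, with a stated time of 72 h (on this read-out lower numbers stand for stronger inhibition and higher numbers for weaker inhibition), compound 3 `CNC(=O)c1cc(Oc2ccc(NC(=O)c3cc(-c4ccccc4)ncn3)cc2)ccn1` gives 18200 nM, the only true number in this small set. Compound 1 `CNC(=O)c1cc(Oc2ccc(NC(=O)c3cc(-c4ccc(C(F)(F)F)cc4)ncn3)cc2F)ccn1` is recorded only as a limit, > 100000 nM. Compound 2 `CNC(=O)c1cc(Oc2ccc(NC(=O)c3cc(-c4ccc(Br)cc4)ncn3)cc2F)ccn1` is likewise recorded only as a limit, > 100000 nM. Both therefore sit at the limit of > 100000 nM in this assay, at which 2 of the 3 values shown sit.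

Compound 4 `CNC(=O)c1cc(Oc2ccc(NC(=O)c3cc(-c4ccccc4)ncn3)cc2F)ccn1` differs from compound 3 by fluoro in place of hydrogen on an aromatic carbon, ortho to a (2-(methylcarbamoyl)pyridin-4-yl)oxy group. The two limit compounds carry this fluoro as well, but each also bears a further group, trifluoromethyl or bromo, that compound 4 lacks. Within the data shown here, the one measured step, a step that the two limits leave unreadable from compound 1 to compound 2, exchanges those two groups and leaves the fluoro untouched, so no measured step isolates the change.

The expectation therefore rests on compound 3 at 18200 nM, with a slight drift towards weaker inhibition and nothing expected beyond the scatter. The expected size of the change is a 1.4-fold higher number from compound 3 to compound 4 (0.14 log units; within the scatter). For compound 4 the estimate is 25000 nM, with an expected range of 8000 nM to 80000 nM.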

Compound 4, half-maximal inhibitory concentration: 32400 nM
The estimate for compound 4 lay 1.3-fold (0.11 log units) below the measured number, and the stated range covers the measured number.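

In this assay, within the data shown here, the fluoro, ortho to a (2-(methylcarbamoyl)pyridin-4-yl)oxy group, is seen on its own for the first time, and it makes little difference: a 1.8-fold higher number from compound 3 to compound 4 (0.25 log units; within the scatter). With that fluoro kept, taking away the further group gives an at least 3.0-fold lower number from compound 2 to compound 4 (0.48 log units; beyond the scatter) for bromo and an at least 3.0-fold lower number from compound 1 to compound 4 (0.48 log units; beyond the scatter) for trifluoromethyl, so the shift to the limit goes with those two groups and not with the fluoro. Both steps are bounds and not exact sizes, as compound 1 and compound 2 are recorded only as limits: the limit of > 100000 nM in this assay, at which 2 of the 4 values shown sit.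

As far as these compounds go, whether bromo or trifluoromethyl would still reach that limit without the fluoro stays open. So does the outcome in this assay of a chloro or a methyl in the fluoro's place, or of an amine or a carboxylic acid where bromo stands.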